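Second chloro on the benzyl arm: expectation for compound 4

The source may hold more compounds than are shown below. What is called first, only, known or untested is meant among the compounds shown, and "the series" means these compounds.

Measured values in a functional assay on A549 cells (Homo sapiens) for cytotoxicity, read by MTT assay, with a stated time of 72 h; a higher number here means a weaker inhibitor, a lower number a stronger inhibitor:

compound 1 `CN(C)Cc1ccc2nc(NC(=O)N/N=C/c3cn(Cc4ccccc4Cl)c4ccccc34)sc2c1` — 1080 nM
compound 2 `CN(C)Cc1ccc2nc(NC(=O)N/N=C3\C(=O)Nc4ccc(Cl)cc43)sc2c1` — 3180 nM
compound 3 `CC1CCN(Cc2ccc3nc(NC(=O)N/N=C4\C(=O)Nc5ccc(F)cc54)sc3c2)CC1` — 3010 nM

Compound 1 gives the lowest number of the three. Compound 3 and compound 2 both give higher numbers than compound 1, and each of these gaps lies beyond the usual scatter, so compound 1 is the strongest inhibitor of the measured set. Among the measured compounds shown here, compound 2 and compound 3 differ from compound 1 in more than one place, so no single-point step between measured compounds is available; the pairs show only their two values.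

Compound 4 `CN(C)Cc1ccc2nc(NC(=O)N/N=C/c3cn(Cc4ccc(Cl)cc4Cl)c4ccccc34)sc2c1` differs from compound 1 in one place: chloro in place of hydrogen on an aromatic carbon. For the measured compounds named here, no measured pair isolates this change, so the expectation rests on compound 1 alone, which gives 1080 nM in this assay. The step from compound 1 to compound 4 is expected to be small, a 1.1-fold lower number from compound 1 to compound 4 (0.06 log units; within the scatter), not beyond the scatter in either direction. Compound 4 is therefore estimated at 950 nM in this assay, with a range from 350 nM to 2600 nM.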

Compound 4, half-maximal inhibitory concentration: 2000 nM
Compound 4: middle estimate off by 2.1-fold (0.32 log units), on the low side; the measured number falls inside the stated range.
By their numbers in this assay, from the lowest: compounds 1, 4, 3 and 2 (each within the scatter of the next, the first and the last beyond it).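

In this assay, among the compounds shown here, the change from 2-chlorobenzyl to 2,4-dichlorobenzyl gives a 1.9-fold higher number from compound 1 to compound 4 (0.27 log units; within the scatter), the first step that isolates a single place. This step lies within the scatter, so compound 1 and compound 4 cannot be ordered, and the aromatic carbon para to the large group and meta to the existing chloro group accepts a second chloro without a readable change in this read-out. No measurement is at hand that bears on the size of this step.

From the compounds shown here alone, one pair covers one substituent at one position, so whether a methoxy group, an amine or a carboxylic acid on this same carbon would also stay within the scatter of compound 1 remains open. Also open, going by these compounds, are what an unsubstituted benzyl arm would give, which would show what the existing chloro group contributes, and whether the step would keep its size on the cores of compound 2 and compound 3.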